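Swapping vinyl for furan-2-yl on a carbonyl carbon

The source may report more compounds than this note shows. Statements on the series, on what has been measured and on what is new or still open speak of the compounds shown alone.

Measured in a functional assay on A-375 cells (Homo sapiens) for cytotoxicity, read by MTT assay; on this read-out lower numbers stand for stronger inhibition and higher numbers for weaker inhibition:
- compound 1 `C#CCOc1cc(/C=C/C(=O)c2ccc(OC)c3c2OC(C)(C)C=C3)ccc1OC`: > 10000 nM (a limit)
- compound 2 `C=CCOc1cc(/C=C/C(=O)c2ccc(OC)c3c2OC(C)(C)C=C3)ccc1OC`: > 10000 nM (a limit)
- compound 3 `C=CC(=O)Oc1cc(/C=C/C(=O)c2ccc(OC)c3c2OC(C)(C)C=C3)ccc1OC`: 390 nM

Compound 1 and compound 2 stop at the limit of > 10000 nM in this assay, at which 2 of the 3 values shown sit. Going by the values given here, compound 3, at 390 nM, is the only one with a real number, and it is the most potent of the three.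

Compound 4 `COc1ccc(/C=C/C(=O)c2ccc(OC)c3c2OC(C)(C)C=C3)cc1OC(=O)c1ccco1` puts furan-2-yl in place of vinyl on a carbonyl carbon.

Among the compounds with values here, two steps bear on this: an at least 25-fold lower number from compound 1 to compound 3 (1.40 log units; beyond the scatter) and an at least 25-fold lower number from compound 2 to compound 3 (1.40 log units; beyond the scatter). Both are large, and both bring in the carbonyl that compound 4 keeps, though neither alters what sits on that carbonyl. The third, a step that the two limits leave unreadable from compound 1 to compound 2, cannot be read. In this assay, compound 4 is therefore expected to give a real number, probably a moderately higher one, with wide uncertainty. The expected change is a 3.8-fold higher number from compound 3 to compound 4 (0.59 log units; beyond the scatter). Compound 4 is estimated at 1500 nM, with a range of 300 nM to 8000 nM.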

Compound 4, half-maximal inhibitory concentration: 680 nM
The estimate for compound 4 lay 2.2-fold (0.34 log units) above the measured number, within the range that was stated.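

In this assay, furan-2-yl can take the place of vinyl on the carbonyl carbon with no readable loss: there is a 1.7-fold higher number from compound 3 to compound 4 (0.24 log units; within the scatter). The advantage of a carbonyl-bearing group on this oxygen over allyl and propargyl therefore holds with a second group, with an at least 14-fold lower number from compound 2 to compound 4 (1.16 log units; beyond the scatter) and an at least 14-fold lower number from compound 1 to compound 4 (1.16 log units; beyond the scatter). Both of these steps start from a limit rather than a real number: the limit of > 10000 nM in this assay, at which 2 of the 4 values shown sit.

On these data alone, how far the group on the carbonyl carbon can vary remains open, as only vinyl and furan-2-yl stand there. A methyl, a longer saturated chain or an amine in that place would test whether activity depends on that group at all.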